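Aryl amine variation in a cytotoxicity series

The source may report more compounds than this note shows. Statements on the series, on what has been measured and on what is new or still open speak of the compounds shown alone.

Measured so far:
Compound 1 `Cc1nc(Nc2ccc(Cl)cc2)sc1C(=O)/C=C/c1ccccc1`: in a functional assay on NCI-H460 cells (Homo sapiens) for cytotoxicity, read by MTT assay (a lower number here means a stronger inhibitor, a higher number a weaker inhibitor), compound 1 reaches only the limit > 25000 nM.
Compound 2 `Cc1ccccc1Nc1nc(C)c(C(=O)/C=C/c2ccc(Cl)cc2)s1`: in this assay compound 2 reaches only the limit > 25000 nM.
Compound 3 `Cc1cccc(Nc2nc(C)c(C(=O)/C=C/c3ccccc3)s2)c1`: in this assay compound 3 gives 21800 nM.

Compound 2 stands at the limit of this assay; no number is known for it, and it shares that standing with compound 1, see (the limit of > 25000 nM in this assay, at which 2 of the 3 values shown sit). Only compound 3 has a measured number, and that number is weak.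

Compound 4 `Cc1nc(Nc2ccc(Cl)c(Cl)c2)sc1C(=O)/C=C/c1ccc(Cl)cc1` differs from compound 2 in one place: 3,4-dichlorophenyl in place of 2-methylphenyl on a nitrogen on an aromatic ring. Among the compounds with values here, the only measured step that touches the group on this nitrogen is an at least 1.1-fold lower number from compound 1 to compound 3 (0.05 log units; that floor lies within the scatter), which is a change between a methylphenyl and a chlorophenyl and stays within the scatter. Nothing measured separates a 2-methylphenyl from a 3,4-dichlorophenyl. Because compound 1, carrying a chlorinated phenyl on the same nitrogen, sits at > 25000 nM, compound 4 is expected to stay in the same weak region. The expected step that the limit leaves unreadable from compound 2 to compound 4 is therefore none beyond the scatter, and the estimate for compound 4 in this assay is 30000 nM, with a range from 10000 nM to 100000 nM, most likely reported again as a limit.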

Compound 4, half-maximal inhibitory concentration: > 25000 nM
Compound 4 was reported as a limit; the forecaster's own chance of this, stated with the estimate: 60%; the middle value lies beyond the limit too.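

In this assay compound 2 and compound 4 are both limits rather than numbers, and no step between them can be read: the limit of > 25000 nM in this assay, at which 3 of the 4 values shown sit.

Open remains whether 2-methylphenyl and 3,4-dichlorophenyl on this nitrogen differ at all in this assay, and how the group on this nitrogen acts once a compound gives a measured number.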